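The compounds below may be only part of what the source reports. "The series", "measured", "known", "first", "only" and "open" are said of these compounds alone.

Values measured in a physicochemical assay, read by spectrophotometry, with a stated time of 6 min; on this read-out higher numbers stand for weaker inhibition and lower numbers for stronger inhibition:
- compound 1 `O=C(CCc1nc2ccccc2c(=O)[nH]1)N/N=C/c1ccc(O)c(O)c1`: 40000000 nM
- compound 2 `O=C(CCc1nc2ccccc2c(=O)[nH]1)N/N=C/c1ccc([N+](=O)[O-])cc1`: 220000000 nM
- compound 3 `COc1cc(/C=N/NC(=O)CCCc2nc3ccccc3c(=O)[nH]2)ccc1O`: 115000000 nM

Compound 3 gives 115000000 nM in this assay, which lies within the scatter of the number for compound 2. The number for compound 1 is lower, and that gap lies beyond the scatter. The next compound, compound 4 `COc1cc(/C=N/NC(=O)CCCc2nc3ccccc3c(=O)[nH]2)cc(O)c1O`, is unmeasured. It differs from compound 3 by a single change: hydroxy in place of hydrogen on an aromatic carbon.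

Going by the values given here, only one measured step touches this part of the molecules, a 5.5-fold higher number from compound 1 to compound 2 (0.74 log units; beyond the scatter), and it swaps the whole aryl group rather than adding one hydroxy. It shows that the 3,4-dihydroxyphenyl compound carries the lower number of that pair. Compound 3 also differs from compound 1 in more than one place, so the number of compound 1, 40000000 nM, is only a rough guide. Compound 4 gains a hydroxy group on an aromatic carbon ortho to a hydroxy group, so a move toward lower numbers in this assay is expected, though smaller than the measured step and possibly no larger than the scatter.

The expected change is a 1.9-fold lower number from compound 3 to compound 4 (0.28 log units; within the scatter). For compound 4 the estimated value is 60000000 nM, with an expected range from 25000000 nM to 130000000 nM.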

Compound 4, half-maximal inhibitory concentration: 50000000 nM
Beside the measured number, compound 4's estimate is 1.2-fold (0.08 log units) above it, and the stated range covers the measured number.
By their numbers in this assay, from the lowest: compounds 1 and 4 (each within the scatter of the next); then compounds 3 and 2 (each within the scatter of the next).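

In this assay, hydroxy in place of hydrogen on the aromatic carbon ortho to a hydroxy group and meta to a methoxy group gives a 2.3-fold lower number from compound 3 to compound 4 (0.36 log units; beyond the scatter), so a change at this one position moves the number toward stronger inhibition. Going by these compounds alone, the only earlier step, a 5.5-fold higher number from compound 1 to compound 2 (0.74 log units; beyond the scatter), exchanged the whole aryl group and could not isolate any single position, whereas here one added hydroxy, a single heavy atom, takes the number beyond the usual scatter, although the step remains modest. No measurement is available to explain why this added hydroxy lowers the number.

The compounds shown leave open whether the hydroxy group itself is needed at this aromatic carbon, or whether an amine or a fluorine atom placed there would lower the number in the same way. They also leave open whether the same hydroxy addition would give a step of similar size on the shorter chain carried by compound 1 , or on a longer chain than that of compound 3 .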